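Notes: 4-methoxybenzyl to 3,4-dichlorobenzyl on the sulfur

The source may hold more compounds than are shown below. What is called first, only, known or untested is meant among the compounds shown, and "the series" means these compounds.

Measured in an ADME assay on HepG2 cells (Homo sapiens) for cytotoxicity, with a stated time of 48 h; a lower number here means a stronger inhibitor, a higher number a weaker inhibitor:
compound 1 `COc1ccc(CSc2nnc(-c3cc([N+](=O)[O-])cc([N+](=O)[O-])c3)n2Cc2ccccc2)cc1`: > 30000 nM
compound 2 `COc1ccc(CSc2nnc(-c3cc([N+](=O)[O-])cc(C(F)(F)F)c3)n2Cc2ccccc2)cc1`: > 30000 nM

Compound 2 gives only a limit, > 30000 nM. Compound 1 also gives only a limit, > 30000 nM. Compound 3 `O=[N+]([O-])c1cc(-c2nnc(SCc3ccc(Cl)c(Cl)c3)n2Cc2ccccc2)cc(C(F)(F)F)c1` carries 3,4-dichlorophenyl in place of 4-methoxyphenyl on a saturated chain carbon bound to a sulfur. Within the data shown here, the one measured step, a step that the two limits leave unreadable from compound 1 to compound 2, concerns trifluoromethyl in place of nitro and has no readable size. Both measured compounds sit at the limit of > 30000 nM in this assay, at which 2 of the 2 values shown sit. No step size can be drawn from this, so no step beyond the scatter is expected in this assay, though a number under the limit remains possible. The estimate for compound 3 is an expected 30000 nM, with an expected range from 12000 nM to 60000 nM. The expected step is a number no higher from compound 2 to compound 3 (the limit leaves the size open).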

Compound 3, half-maximal inhibitory concentration: > 30000 nM
Compound 3: no number, only a limit; the forecaster's own chance of this, stated with the estimate: 70%; the middle value lies on the limit itself.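

In this assay compound 3 gives only a limit, > 30000 nM. Among these compounds, compound 2 also gives only a limit, so no step from compound 2 to compound 3 can be read. The compounds shown leave open how 3,4-dichlorobenzyl and 4-methoxybenzyl on the sulfur compare in this assay.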